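The source may report more compounds than this note shows. Statements on the series, on what has been measured and on what is new or still open speak of the compounds shown alone.

Measured so far, in an assay on CHO cells for antagonist activity at transient receptor potential cation channel subfamily V member 1 (Homo sapiens), read by FLIPR; a lower number here means a stronger inhibitor, a higher number a weaker inhibitor:
compound 1 `CC(C(=O)NCc1ccc(C(F)(F)F)cc1N1CCCCCC1)c1ccc(NS(C)(=O)=O)c(F)c1` gives 1.6 nM;
compound 2 `CC1CCN(c2cc(C(F)(F)F)ccc2CNC(=O)C(C)c2ccc(NS(C)(=O)=O)c(F)c2)CC1` gives 0.9 nM;
compound 3 `CC(C(=O)NCc1ccc(C(F)(F)F)cc1N1CCC(C(F)(F)F)CC1)c1ccc(NS(C)(=O)=O)c(F)c1` gives 0.4 nM.

Compound 3 stands lowest of the three, and both of its gaps are beyond the scatter: a 4.0-fold lower number from compound 1 to compound 3 (0.60 log units; beyond the scatter) and a 2.3-fold lower number from compound 2 to compound 3 (0.35 log units; beyond the scatter). Between compound 1 and compound 2 the difference stays within the scatter: a 1.8-fold lower number from compound 1 to compound 2 (0.25 log units; within the scatter).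

Compound 4 `CC(C(=O)NCc1ccc(C(F)(F)F)cc1OC1CCCCC1)c1ccc(NS(C)(=O)=O)c(F)c1` has not yet been measured in this assay. It differs from compound 3 in one place: cyclohexyloxy in place of 4-(trifluoromethyl)piperidin-1-yl on an aromatic carbon. 

None of the measured steps swaps the ring itself or the atom through which it hangs on the aromatic carbon; they only vary the ring size or the group on a saturated ring carbon, with modest effects as shown above. The change to compound 4 is therefore a step into unknown ground, and the most that can be said is that it removes the trifluoromethyl on the saturated ring, which in compound 2 to compound 3 brought a modest gain. A modest rise in number is expected for compound 4, as a 3.8-fold higher number from compound 3 to compound 4 (0.57 log units; beyond the scatter), with wide uncertainty. Compound 4 is estimated at 1.5 nM, within a range from 0.4 nM to 6 nM.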

Compound 4, inhibition constant: 0.7 nM
Compound 4: the middle estimate sits 2.1-fold (0.33 log units) above what was measured; the range from low to high includes it.
By their numbers in this assay, from the lowest: compounds 3, 4, 2 and 1 (each within the scatter of the next, the first and the last beyond it).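

Until now every group on this aromatic carbon was attached through a ring nitrogen. Compound 4 shows that cyclohexyloxy, a carbon-only ring attached through oxygen, also fits in this assay, with a 1.8-fold higher number from compound 3 to compound 4 (0.24 log units; within the scatter) and a 1.3-fold lower number from compound 2 to compound 4 (0.11 log units; within the scatter). Set against the azepan-1-yl group, the same change gives a 2.3-fold lower number from compound 1 to compound 4 (0.36 log units; beyond the scatter), so a low number at this position needs neither the ring nitrogen nor a trifluoromethyl on the saturated ring, and no measurement at hand bears on why these groups give such similar numbers.

Still open, from the compounds shown here alone, is whether a trifluoromethyl on the cyclohexyloxy ring would lower the number, as it did on the piperidine ring. Also open, going by these compounds, is how an open-chain ether such as butoxy, or a piperazine ring carrying a second nitrogen, would behave on this carbon.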